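The compounds below may be only part of what the source reports. "The series", "measured", "known", "first", "only" and "open" are said of these compounds alone.

Measured so far:
- compound 1 `COc1ccc(-c2c(-c3ccccc3)sc(C(C)C)c2/C=C/[C@@H](O)C[C@@H](O)CC(=O)O)cc1`: 2430 nM
- compound 2 `CC(C)c1sc(-c2ccccc2)c(-c2ccc(-c3ccccc3)cc2)c1/C=C/[C@@H](O)C[C@@H](O)CC(=O)O`: see below
- compound 3 `CC(C)=Cc1sc(C(C)C)c(/C=C/[C@@H](O)C[C@@H](O)CC(=O)O)c1-c1ccc(F)cc1`: 15 nM

In an assay on microsomes for inhibition of 3-hydroxy-3-methylglutaryl-coenzyme A reductase (Rattus norvegicus) (a higher number here means a weaker inhibitor, a lower number a stronger inhibitor), compound 3 holds the lowest of the two numbers; the nearest, compound 1, sits far above it. In this assay compound 2 gives > 10000 nM, which is a limit of the assay, not a number. Going by the values given here, the only measured single-point step, an at least 4.1-fold higher number from compound 1 to compound 2 (0.61 log units; beyond the scatter), runs into (the limit of > 10000 nM in this assay, at which 1 of the 3 values shown sits), so its true size is not known.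

Compound 4 `CC(C)c1sc(-c2ccc(Cl)cc2)c(-c2ccc(F)cc2)c1/C=C/[C@@H](O)C[C@@H](O)CC(=O)O` is the next structure; it differs from compound 3 by 4-chlorophenyl in place of 2-methylprop-1-en-1-yl on an aromatic carbon. Among the compounds with values here, the step from compound 1 to compound 2 is the only comparison at hand: it also places an aryl ring where a smaller group stood and the number rose by at least a modest amount, but the position on the core is not the same, so it guides only loosely. A modest rise in this assay is therefore expected for compound 4, beyond the scatter but well short of the limit.

Compound 4 is estimated at 45 nM, with a range from 9 nM to 250 nM, which means an expected step of a 3.0-fold higher number from compound 3 to compound 4 (0.48 log units; beyond the scatter).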

Compound 4, half-maximal inhibitory concentration: 21 nM
Estimate against measurement, compound 4: 2.1-fold (0.33 log units) above, and the stated range covers the measured number.
By their numbers in this assay, from the lowest: compounds 3 and 4 (each within the scatter of the next); then compound 1. At a limit, above all of these: compound 2.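

In this assay the replacement of 2-methylprop-1-en-1-yl by 4-chlorophenyl gives a 1.4-fold higher number from compound 3 to compound 4 (0.15 log units; within the scatter), so on this aromatic carbon next to the ring sulfur the two groups cannot be told apart. The position therefore takes an aromatic ring of 7 heavy atoms as readily as an open chain of 4 heavy atoms with a double bond, at least with a 4-fluorophenyl group on the ring atom next to it. Nothing measured here accounts for this outcome.

From the compounds shown here alone, whether the chlorine contributes stays open, as an unsubstituted phenyl at this position appears only in compound 1 and compound 2, which also carry a different aryl group elsewhere. Going by these compounds, how an amine, a carboxylic acid or a plain methyl on this carbon would behave in this assay also stays open.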